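Swapping an Amine Side Chain for Chloro

The source may report more compounds than this note shows. Statements on the series, on what has been measured and on what is new or still open speak of the compounds shown alone.

Compound 1 `CNc1nccc(N2CC[C@H](NC(=O)Nc3ccc(CN(C)C)c(C(F)(F)F)c3)C2)n1` reads 94.3% as measured
Compound 2 `CNc1nccc(N2CC[C@H](NC(=O)Nc3cc(OC)cc(OC)c3)C2)n1` reads 98.1% as measured

In an ADME assay on a cell-free system (plasma, Homo sapiens) for protein binding, compound 1 has the higher unbound fraction of the two measured compounds, and its gap to compound 2 lies beyond the scatter. Compound 3 `CNc1nccc(N2CC[C@H](NC(=O)Nc3ccc(Cl)c(C(F)(F)F)c3)C2)n1` carries chloro in place of (dimethylamino)methyl on an aromatic carbon, ortho to a trifluoromethyl group and para to a large group chloro in place of (dimethylamino)methyl on an aromatic carbon and has not yet been measured. Among the compounds with values here, no measured pair shows this change on its own, so any forecast rests on thin evidence. Compound 2 also has no (dimethylamino)methyl and reads 98.1% in this assay so a step towards more binding, beyond the scatter, is expected. The estimated step is a 3.8-fold lower unbound fraction from compound 1 to compound 3 (0.58 log units; beyond the scatter) in this assay. For compound 3 the expected value is 98.5% with an estimated range from 96.5% to 99.5% in this assay.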

Compound 3, plasma protein binding: 99.8%
The estimate for compound 3 lay 7.5-fold (0.88 log units) (unbound fraction) above the measured number; the measured number lies above the stated range.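

In this assay, within the data shown here, the only step that changes a single place falls on the aromatic carbon ortho to a trifluoromethyl group and para to a large group: chloro in place of (dimethylamino)methyl gives a 29-fold lower unbound fraction from compound 1 to compound 3 (1.45 log units; beyond the scatter). With the rest of the structure unchanged, this shows that the group at this one position can by itself shift plasma protein binding by a large amount, which compound 1 and compound 2 could not show, since they differ in more than one place. Nothing on hand accounts for the size of this step.

Among these compounds, the single pair leaves open how much of the step follows from removing (dimethylamino)methyl and how much from adding chloro. A plain hydrogen, a methyl group or a longer aminoalkyl chain at this position would help separate the two.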